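Notes on the furan-to-phenyl exchange in this series

A few compounds are considered here, and "the series" means these few. Any claim that something is new, unique, unknown or untested is made for them only; others in the source may bear on it.

The three measured compounds share one core and differ only in the group on one aromatic carbon. For the measured compounds named here, compound 1 `COc1ncnc2c1c(-c1ccoc1)cn2[C@@H]1O[C@H](CO)[C@@H](O)[C@H]1O` carries a methoxy; in a functional assay on HCT-116 cells (Homo sapiens), read by MTT assay, with a stated time of 72 h (on this read-out lower numbers stand for stronger inhibition and higher numbers for weaker inhibition), compound 1 gives 110 nM, the only numeric value in the set. Compound 2 `CN(C)c1ncnc2c1c(-c1ccoc1)cn2[C@@H]1O[C@H](CO)[C@@H](O)[C@H]1O` carries a dimethylamino in place of the methoxy; in this assay compound 2 gives > 20000 nM, which is a limit of the assay and not a number. Compound 3 `Cc1ncnc2c1c(-c1ccoc1)cn2[C@@H]1O[C@H](CO)[C@@H](O)[C@H]1O` carries a methyl in place of the methoxy; in this assay compound 3 gives > 20000 nM, again a limit. Both steps away from compound 1 are large: an at least 180-fold higher number from compound 1 to compound 2 (2.25 log units; beyond the scatter) and an at least 180-fold higher number from compound 1 to compound 3 (2.25 log units; beyond the scatter), each ending at the limit of > 20000 nM in this assay, at which 2 of the 3 values shown sit. Between them, a step that the two limits leave unreadable from compound 2 to compound 3.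

Compound 4 `COc1ncnc2c1c(-c1ccccc1)cn2[C@@H]1O[C@H](CO)[C@@H](O)[C@H]1O` keeps the methoxy of compound 1 and changes a different part: phenyl in place of furan-3-yl on an aromatic carbon. Going by the values given here, none of the measured steps touches this ring, so they give no direct guide to the size or direction of the change. Among the compounds with values here, the only anchor is the value of compound 1, 110 nM. The expectation is a modest step, a 2.7-fold higher number from compound 1 to compound 4 (0.44 log units; beyond the scatter), with wide uncertainty. Compound 4 is therefore estimated at 300 nM, between 60 nM and 3000 nM.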

Compound 4, half-maximal inhibitory concentration: > 20000 nM
Compound 4 ended at the assay's limit (the forecaster's own chance of this, stated with the estimate: 15%); middle value at least 66-fold (1.82 log units) from the limit.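

Compound 4 keeps the methoxy and changes only the ring, yet phenyl in place of furan-3-yl gives an at least 180-fold higher number from compound 1 to compound 4 (2.25 log units; beyond the scatter) in this assay. The earlier compounds shown here showed that the group on the other aromatic carbon matters, and this step shows the same for the carbon two ring bonds from the ring nitrogen: with the methoxy in place, compound 1 still gives a number and compound 4 does not. In this assay compound 4 gives > 20000 nM, which is a limit of the assay and not a number, and the full size of the step stays unreadable for that reason: the limit of > 20000 nM in this assay, at which 3 of the 4 values shown sit.

The exchange alters ring size and removes the ring oxygen in one move, as a five-membered aromatic ring with 1 hetero atom gives way to a six-membered aromatic ring of carbon only, and the compounds shown do not separate these two changes. Going by these compounds, whether a thienyl or a pyridyl group on this carbon would stay near the value of compound 1, 110 nM, remains open.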